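A few compounds are considered here, and "the series" means these few. Any claim that something is new, unique, unknown or untested is made for them only; others in the source may bear on it.

In a functional assay on MDA-MB-231 cells (Homo sapiens) for inhibition, read by sulforhodamine B assay, with a stated time of 72 h (on this read-out higher numbers stand for weaker inhibition of growth and lower numbers for stronger inhibition of growth), compound 1 `NNC(=O)CCc1ccncc1-c1ccc2ccccc2c1` reports only a limit, > 10000 nM. Among the compounds with values here, compound 2 `CCOC(=O)/C=C/c1ccncc1-c1ccc2ccccc2c1` gives 8090 nM, the only true number available so far. Within the data shown here, the one measured step is an at least 1.2-fold lower number from compound 1 to compound 2 (0.09 log units; that floor lies within the scatter), and it places 2-(ethoxycarbonyl)ethenyl where 2-(aminocarbamoyl)ethyl stood. The next compound, compound 3 `O=C(O)/C=C/c1ccncc1-c1ccc2ccccc2c1`, keeps the shared core and changes one place: hydrogen in place of ethyl on an oxygen next to a carbonyl group, so that ethoxycarbonyl becomes carboxy. The measured step touches the same side chain but involves a different change, so it offers only weak guidance on size or direction. The data also contain (the limit of > 10000 nM in this assay, at which 1 of the 2 values shown sits). A step beyond the scatter is therefore not confidently expected, although a shift toward a higher number seems slightly more likely. The expected change is a 1.2-fold higher number from compound 2 to compound 3 (0.09 log units; within the scatter). For compound 3, the estimated value is 10000 nM, with an expected range of 3500 nM to 30000 nM.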

Compound 3, concentration for 50% growth inhibition: > 10000 nM
Compound 3: a limit, no number; the forecaster's own chance of this, stated with the estimate: 50%; the middle value lies on the limit itself.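

Replacing the ethyl on this oxygen with hydrogen turns the ester side chain into 2-carboxyethenyl, and in this assay compound 3 reports only a limit, > 10000 nM. The change gives an at least 1.2-fold higher number from compound 2 to compound 3 (0.09 log units; that floor lies within the scatter), so carboxy shows no visible gain over ethoxycarbonyl here, although the true size of the step stays hidden. The step between compound 1 and compound 3 cannot be read, as both values are limits, and the series now gathers at that ceiling: the limit of > 10000 nM in this assay, at which 2 of the 3 values shown sit.

On these data alone, it remains open whether a longer ester chain such as propyl, or an amide built from a simple amine, would give a true number at this position. As far as these compounds go, it also remains open how a saturated ethyl link carrying ethoxycarbonyl would compare with the ethenyl link of compound 2.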